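A few compounds are considered here, and "the series" means these few. Any claim that something is new, unique, unknown or untested is made for them only; others in the source may bear on it.

Compound 1 `COc1cc(-c2nn(-c3cccc(NC(=O)Nc4cc(C(F)(F)F)cc(C(F)(F)F)c4)c3)cc2-c2ccncc2)ccc1Cl` and compound 2 `O=C(Nc1cccc(-n2cc(-c3ccncc3)c(-c3ccc(Cl)c(O)c3)n2)c1)Nc1cc(C(F)(F)F)cc(C(F)(F)F)c1` share one core, and compound 2 arises from compound 1 by hydrogen in place of methyl on an oxygen on an aromatic ring. In a functional assay on UACC-62 cells (Homo sapiens) for inhibition, read by sulforhodamine B assay, with a stated time of 48 h (on this read-out lower numbers stand for higher toxicity in this test and higher numbers for lower toxicity in this test), compound 1 gives 3780 nM, and compound 2 gives 8460 nM, which amounts to a 2.2-fold higher number from compound 1 to compound 2 (0.35 log units; beyond the scatter). Compound 3 `COc1cc(-c2nn(-c3cccc(NC(=O)Nc4ccc(Cl)c(C(F)(F)F)c4)c3)cc2-c2ccncc2)ccc1Cl` rests on a different core; the difference between the two cores is not broken down here. In this assay compound 3 gives 11600 nM. Compound 4 `O=C(Nc1cccc(-n2cc(-c3ccncc3)c(-c3ccc(Cl)c(O)c3)n2)c1)Nc1ccc(Cl)c(C(F)(F)F)c1` stands to compound 3 exactly as compound 2 stands to compound 1, through (hydrogen in place of methyl on an oxygen on an aromatic ring), at the same place on the ring. A similar shift is therefore expected, namely a 1.9-fold higher number from compound 3 to compound 4 (0.28 log units; within the scatter), because a 2.2-fold higher number from compound 1 to compound 2 (0.35 log units; beyond the scatter) followed the identical change. Compound 4 is accordingly estimated at 22000 nM, with the likely span running from 9000 nM to 55000 nM.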

Compound 4, concentration lethal to 50% of the cells: 3160 nM
The estimate for compound 4 lay 7.0-fold (0.84 log units) above the measured number; measured number outside the range, below it.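

In this assay, the change from methoxy to hydroxy gave a 3.7-fold lower number from compound 3 to compound 4 (0.56 log units; beyond the scatter), so the direction seen on the core of compound 1 did not carry over to the core of compound 3: the same change on two cores in this assay, a 2.2-fold higher number (0.35 log units; beyond the scatter) from compound 1 to compound 2 and a 3.7-fold lower number (0.56 log units; beyond the scatter) from compound 3 to compound 4, 8.2-fold (0.91 log units) apart, beyond the scatter of two such steps.
Across these two pairs, the outcome of this change differs with the core, and a step measured on one core gave no reliable guide to the other. Two pairs do not show which feature of the cores accounts for the reversal, nor do they give a rule for any further core.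

The compounds shown leave open whether an ethoxy group or a longer chain on that oxygen, or an amine in place of the hydroxy, would follow either pair. They also leave open how the same change would behave on a third core.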